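From phenoxy to hydroxy in compound 3

The compounds below may be only part of what the source reports. "The series", "measured", "known", "first", "only" and "open" are said of these compounds alone.

Measured in an ADME assay on HepG2 cells (Homo sapiens) for cytotoxicity, read by MTT assay, with a stated time of 72 h; a lower number here means that less compound is tolerated, a higher number that more compound is tolerated:
- compound 1 `COc1ccccc1C#Cc1cc(Cl)cn2c([N+](=O)[O-])c(CS(=O)(=O)c3ccccc3)nc12`: > 3900 nM (a limit of the assay)
- compound 2 `O=[N+]([O-])c1c(CS(=O)(=O)c2ccccc2)nc2c(C#CCOc3ccccc3)cc(Cl)cn12`: 8400 nM

Within the data shown here, compound 2, at 8400 nM, holds the only true number in this small set. The other entry is no number: compound 1 gives > 3900 nM, which is a limit. The next compound is compound 3 `O=[N+]([O-])c1c(CS(=O)(=O)c2ccccc2)nc2c(C#CCO)cc(Cl)cn12`, and its difference from compound 2 is hydrogen in place of phenyl on an oxygen on a saturated carbon. The side chain thus goes from 3-phenoxyprop-1-yn-1-yl to 3-hydroxyprop-1-yn-1-yl, with hydrogen in place of phenyl on an oxygen on a saturated carbon.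

Among the measured compounds shown here, the one measured step that bears on this is a step that the limit leaves unreadable from compound 1 to compound 2. It involves the same side chain but offers no size to carry over. The expectation therefore rests on compound 2 at 8400 nM and on the structural change alone, and it is correspondingly loose. A moderate shift towards more compound tolerated in this assay is expected, though a result within the scatter would be no surprise. The expected change is a 2.4-fold higher number from compound 2 to compound 3 (0.38 log units; beyond the scatter). For compound 3 the estimated value is 20000 nM, with an expected range of 7000 nM to 60000 nM.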

Compound 3, half-maximal cytotoxic concentration: 10100 nM
For compound 3 the middle estimate is 2.0-fold (0.30 log units) above the measured one; the range from low to high includes it.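

In this assay, taking the phenyl off the oxygen on the saturated carbon, so that 3-phenoxyprop-1-yn-1-yl becomes 3-hydroxyprop-1-yn-1-yl, gives a 1.2-fold higher number from compound 2 to compound 3 (0.08 log units; within the scatter). Among these compounds, this is the first readable step, and it shows that the whole aromatic ring at the end of this side chain can go without the number in this assay moving beyond the usual scatter, so for this one pair the phenyl makes no measurable difference to how much compound the cells tolerate. The steps that start from compound 1, whose 2-methoxyphenyl sits directly on the triple-bonded carbon, cannot be read and so say nothing about how that group compares with either side chain, because the entry for compound 1 is a limit and not a number: the limit of > 3900 nM in this assay, at which 1 of the 3 values shown sits.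

The compounds shown leave open whether this indifference holds only for phenyl and hydrogen on that oxygen, or whether an amine in place of the hydroxy group would also leave the number where it is. They also leave open what a longer chain between the triple bond and the oxygen would do, since every oxygen-bearing side chain here has the same length.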